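Hydroxyphenyl pyridines: furan-2-yl replacement at the ring nitrogen position

A few compounds are considered here, and "the series" means these few. Any claim that something is new, unique, unknown or untested is made for them only; others in the source may bear on it.

Compound 2 `Oc1ccc(-c2cc(-c3ccncc3)nc(-c3ccc(Cl)cc3)c2)cc1` carries a 4-hydroxyphenyl, a pyridin-4-yl and a 4-chlorophenyl group on the shared core, but in a functional assay on DU-145 cells (Homo sapiens) for cytotoxicity, read by CCK-8 assay and cell counting, with a stated time of 2 days (a higher number here means a weaker inhibitor, a lower number a stronger inhibitor), compound 2 has "not determined" (no result reported), so it stands on no number. Its closest measured relatives are compound 1 `Oc1cccc(-c2cc(-c3cccc(Cl)c3)nc(-c3cccs3)c2)c1`, which in this assay gives 2650 nM, and compound 3 `Oc1cccc(-c2cc(-c3ccncc3)nc(-c3ccc(Cl)cc3)c2)c1`, which in this assay gives 2510 nM; these two values lie within the scatter of each other. Compound 4 `Oc1ccc(-c2cc(-c3ccc(Cl)cc3)nc(-c3ccco3)c2)cc1` differs from compound 2 as follows: furan-2-yl in place of pyridin-4-yl on an aromatic carbon. With no number for compound 2, the step itself cannot be sized; on the values of compound 1 and compound 3, no shift beyond the scatter is expected. Compound 4 is estimated at 2800 nM, within 900 nM to 9000 nM.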

Compound 4, half-maximal inhibitory concentration: 7280 nM
For compound 4 the middle estimate is 2.6-fold (0.41 log units) below the measured one; the measured number falls inside the stated range.
By their numbers in this assay, from the lowest: compounds 3 and 1 (each within the scatter of the next); then compound 4.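

With no number for compound 2 in this assay, the step from pyridin-4-yl to furan-2-yl leading to compound 4 cannot be read. From the compounds shown here alone, how that swap alone shifts the value stays open. No supporting evidence bears on this result.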